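Bromophenoxy series: moving to 4-chlorophenoxy

The source may hold more compounds than are shown below. What is called first, only, known or untested is meant among the compounds shown, and "the series" means these compounds.

The three measured compounds share the core of compound 1 `NC1=NC2(CCSCC2)N(OCCCOc2ccc(Br)cc2)C(N)=N1` and differ only in the aryl group on an oxygen on a saturated carbon. In an assay on isolated protein for inhibition of Dihydrofolate reductase (Homo sapiens), read by spectrophotometry, using NADPH, with stated times of 5 s and 6 min, tested at 5 uM (a lower number here means a weaker effect, a higher number a stronger effect of the compound at the concentration tested), compound 1 gives > 90%, which is a limit of the assay (the limit of > 90% in this assay, at which 1 of the 3 values shown sits). Compound 2 `NC1=NC2(CCSCC2)N(OCCCOc2ccccc2Br)C(N)=N1` gives 88.7%. Compound 3 `NC1=NC2(CCSCC2)N(OCCCOc2cccc(Br)c2)C(N)=N1` gives 84.2%, the smaller of the two plain numbers, yet a number 4.5 percentage points lower from compound 2 to compound 3 (within the scatter). Likewise a number at least 5.8 percentage points lower from compound 1 to compound 3 (that floor lies within the scatter) and a number at least 1.3 percentage points lower from compound 1 to compound 2 (that floor lies within the scatter). Compound 4 `NC1=NC2(CCSCC2)N(OCCCOc2ccc(Cl)cc2)C(N)=N1` is not yet measured; the change is 4-chlorophenyl in place of 3-bromophenyl on an oxygen on a saturated carbon. Among the compounds with values here, the 4-chlorophenyl group recalls the 4-bromophenyl of compound 1, so a modest rise is expected, a number 3.8 percentage points higher from compound 3 to compound 4 (within the scatter), though no measured step covers bromine against chlorine. Compound 4 is expected at 88%, between 80% and 94%.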

Compound 4, a percentage reported as inhibition, at one concentration (the size of the read-out at that concentration, not a potency): > 90%
Compound 4: only a limit was reported; the forecaster's own chance of this, stated with the estimate: 30%; middle value at least 2 percentage points away from the limit.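

In this assay compound 4 gives > 90%, which is a limit of the assay. A chlorine-bearing aryl group on this oxygen thus also reaches that limit, with a number at least 5.8 percentage points higher from compound 3 to compound 4 (that floor lies within the scatter) and a number at least 1.3 percentage points higher from compound 2 to compound 4 (that floor lies within the scatter). The step between the two 4-halophenyl compounds cannot be read: the limit of > 90% in this assay, at which 2 of the 4 values shown sit.

Going by these compounds, whether chloro and bromo differ at all on this ring stays open while both compounds sit at the limit. Also open, on these data alone, is how a plain phenyl, a nitrile or a carboxylic acid in place of the halogen would read.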